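This account rests on a few compounds, and the source may have more. Where it says the series, first, only, none or still open, it means among the compounds named here.

Measured compounds:
compound 1 `COc1ccc(-c2c(S(=O)(=O)c3cc(Cl)cc(Cl)c3)cnc3cc(F)ccc23)cc1` with 1 mL/min
compound 2 `COc1cccc(S(=O)(=O)c2cnc3cc(F)ccc3c2-c2cccc(Cl)c2)c1` with 2.97 mL/min
compound 3 `N#Cc1cccc(S(=O)(=O)c2cnc3cc(F)ccc3c2-c2cccc(Cl)c2)c1` with 0.99 mL/min

In an ADME assay on microsomes from liver (Homo sapiens) for metabolic stability, tested at 2.5 uM (on this read-out lower numbers stand for slow clearance and higher numbers for fast clearance), compound 3 stands lowest of the three numbers; compound 1 is within the scatter of it, while compound 2 lies beyond it. Compound 4 `O=S(=O)(c1cc(Cl)cc(Cl)c1)c1cnc2cc(F)ccc2c1-c1cccc(Cl)c1` is not yet measured. It differs from compound 3 by 3,5-dichlorophenyl in place of 3-cyanophenyl on a sulfonyl sulfur. Among the compounds with values here, the single known step, a 3.0-fold lower number from compound 2 to compound 3 (0.48 log units; beyond the scatter), concerns the same group on the sulfonyl sulfur but a different exchange, so it bears only loosely on this one. Compound 1, which carries the same 3,5-dichlorophenyl on the sulfonyl sulfur, gives 1 mL/min. On that basis compound 4 is expected near compound 3, with a step of about a 1.3-fold higher number from compound 3 to compound 4 (0.12 log units; within the scatter) that stays within the scatter, and its value in this assay is estimated at 1.3 mL/min (range 0.5 mL/min to 3.5 mL/min).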

Compound 4, intrinsic clearance in a liver preparation (reported as CLH), per the amount of preparation that the assay uses: 0.93 mL/min
Beside the measured number, compound 4's estimate is 1.4-fold (0.15 log units) above it; low and high end bracket the measured number.
By their numbers in this assay, from the lowest: compounds 4, 3 and 1 (each within the scatter of the next); then compound 2.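

In this assay the sulfonyl sulfur accepts 3,5-dichlorophenyl as readily as 3-cyanophenyl (a 1.1-fold lower number from compound 3 to compound 4 (0.03 log units; within the scatter)), whereas the same group in place of 3-methoxyphenyl gives a clear drop (a 3.2-fold lower number from compound 2 to compound 4 (0.50 log units; beyond the scatter)). Among these three groups on this sulfur, only 3-methoxyphenyl stands apart. With 3,5-dichlorophenyl held on the sulfonyl sulfur, 3-chlorophenyl in place of 4-methoxyphenyl on the aromatic carbon changes little (a 1.1-fold lower number from compound 1 to compound 4 (0.03 log units; within the scatter)). Going by these compounds, how an amine such as morpholine would read on that aromatic carbon remains open. No measurement shown explains these numbers.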